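Chromone series: diol ether replaced by chlorobenzyl ether

The compounds below may be only part of what the source reports. "The series", "measured", "known", "first", "only" and "open" are said of these compounds alone.

Three compounds of the shared core carry a measurement in a functional assay for inhibition; a lower number here means a stronger inhibitor, a higher number a weaker inhibitor. Compound 1 `CC(C)(C)c1cc(-c2cc(=O)c3ccc(OCC(=O)N4CCN(Cc5ccccc5)CC4)cc3o2)cc(C(C)(C)C)c1O` gives 3000 nM. Compound 2 `CC(C)(C)c1cc(-c2cc(=O)c3ccc(OCC(O)CO)cc3o2)cc(C(C)(C)C)c1O` gives 100 nM, the lowest of the three numbers, with compound 1 beyond the scatter above it. Compound 3 `CC(C)(C)c1cc(C(=O)Oc2ccc3c(=O)cc(-c4cc(C(C)(C)C)c(O)c(C(C)(C)C)c4)oc3c2)cc(C(C)(C)C)c1O` gives 30000 nM, the furthest from compound 2. Among the measured compounds shown here, no pair of these differs in one place only, so no single step can be read off.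

Compound 4 `CC(C)(C)c1cc(-c2cc(=O)c3ccc(OCc4ccc(Cl)cc4)cc3o2)cc(C(C)(C)C)c1O` is the next member. From compound 2 it differs thus: 4-chlorophenyl in place of 1,2-dihydroxyethyl on a saturated chain carbon bound to an oxygen on an aromatic ring. Both larger substituents measured so far sit well above compound 2, so a weakening step is expected, estimated as a 15-fold higher number from compound 2 to compound 4 (1.18 log units; beyond the scatter), because compound 1 gives 3000 nM. Compound 4 is therefore expected at 1500 nM, within 300 nM to 8000 nM.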

Compound 4, half-maximal inhibitory concentration: 7000 nM
The estimate for compound 4 lay 4.7-fold (0.67 log units) below the measured number; measured number inside the range.
By their numbers in this assay, from the lowest: compound 2; then compound 1; then compound 4; then compound 3.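

In this assay, this position now has its first single-place change, and the step is large (a 70-fold higher number from compound 2 to compound 4 (1.85 log units; beyond the scatter)). Replacing 1,2-dihydroxyethyl with 4-chlorophenyl on this saturated chain carbon removes both hydrogen-bond donors and both acceptors and introduces an aromatic ring, so the number at this position depends strongly on the group carried there. Nothing available bears on the cause of this step.

Among the compounds shown here, the single step cannot separate loss of the hydroxyl groups from gain of the ring. On these data alone, whether an unsubstituted benzyl, a 2-hydroxyethyl or an aminoethyl group here would stay closer to compound 2 or to compound 4 remains open.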